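Working notes: from compound 3 to compound 4

The source may report more compounds than this note shows. Statements on the series, on what has been measured and on what is new or still open speak of the compounds shown alone.

Measured in a functional assay on MT4 cells (Homo sapiens); on this read-out lower numbers stand for higher toxicity in this test and higher numbers for lower toxicity in this test:
- compound 1 `Cc1cn([C@@H]2O[C@@H]3COC(=O)[C@]3(OS(C)(=O)=O)[C@H]2O)c(=O)[nH]c1=O`: >= 250000 nM (a limit)
- compound 2 `C=C(C)C(=O)NC(=O)NC1=CS(=O)(=O)O[C@@]12[C@@H](CO[Si](C)(C)C(C)(C)C)O[C@@H](n1cc(C)c(=O)n(C)c1=O)[C@@H]2O[Si](C)(C)C(C)(C)C`: 1190 nM
- compound 3 `CCOC(=O)CNC(=O)NC1=CS(=O)(=O)O[C@@]12[C@@H](CO[Si](C)(C)C(C)(C)C)O[C@@H](n1cc(C)c(=O)n(C)c1=O)[C@@H]2O[Si](C)(C)C(C)(C)C`: 3780 nM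

The entry for compound 1 is a limit of the assay and not a number.

Of the two actual numbers, compound 3 holds the higher at 3780 nM, and compound 2 holds the lower at 1190 nM.

Compound 4 `Cc1cn([C@@H]2O[C@H](CO[Si](C)(C)C(C)(C)C)[C@@]3(OS(=O)(=O)C=C3NCC(=O)C(=O)O)[C@H]2O[Si](C)(C)C(C)(C)C)c(=O)n(C)c1=O` is the next to be read in this assay. Its difference from compound 3 is (carboxycarbonyl)methyl in place of ((ethoxycarbonyl)methyl)carbamoyl on an amine nitrogen.

For the measured compounds named here, no measured step covers this exchange directly. Going by the values given here, the only guide to size is a 3.2-fold higher number from compound 2 to compound 3 (0.50 log units; beyond the scatter), a modest step that came from (ethoxycarbonyl)methyl in place of (1-methylethenyl)carbonyl on an amide-type nitrogen. That single step gives no direction for the new change, so a shift of similar or smaller size is the working expectation, with a slight lean towards higher numbers.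

The step expected is a 1.2-fold higher number from compound 3 to compound 4 (0.08 log units; within the scatter), and a move beyond the scatter would not be a surprise.

The estimated value for compound 4 is 4500 nM, with an expected range of 1300 nM to 16000 nM.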

Compound 4, half-maximal cytotoxic concentration: 31100 nM
The estimate for compound 4 lay 6.9-fold (0.84 log units) below the measured number; measured number above the stated range.
By their numbers in this assay, from the lowest: compound 2; then compound 3; then compound 4. At a limit, above all of these: compound 1.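

In this assay, exchanging ((ethoxycarbonyl)methyl)carbamoyl for (carboxycarbonyl)methyl on the amine nitrogen gives an 8.2-fold higher number from compound 3 to compound 4 (0.92 log units; beyond the scatter), so this position responds clearly to a change that removes the carbamoyl link itself, whereas the earlier pair differed only further out along that substituent. The same exchange measured against the other carbamoyl-bearing compound gives a 26-fold higher number from compound 2 to compound 4 (1.42 log units; beyond the scatter), so compound 4 lies beyond the scatter from both compounds that carry a carbamoyl group on this nitrogen, and in the same direction, towards lower toxicity in this test. Nothing measured in this series accounts for that rise.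

The exchange alters the link to the nitrogen and the end of the chain at once, so the rise cannot yet be assigned to the loss of the carbamoyl group or to the arrival of the carboxylic acid. A carbamoyl chain ending in a carboxylic acid, or a plain amine at this nitrogen with no chain at all, would separate those two contributions on the shared core.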